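Swapping Methyl for Difluoromethyl on Compound 3

The source may hold more compounds than are shown below. What is called first, only, known or untested is meant among the compounds shown, and "the series" means these compounds.

Of the compounds shown here, three built on one shared core have been measured in an ADME assay on cells for inhibition of cytochrome P450 11B1, mitochondrial (Homo sapiens), read by HPLC, with a stated time of 60 min; on this read-out higher numbers stand for weaker inhibition and lower numbers for stronger inhibition. Compound 1 `Fc1ccc2nc(-c3cnco3)n(C3CC3)c2c1` gives only a limit there, > 10000 nM. Compound 2 `Fc1ccc2nc(-c3cncs3)n(C3CC3)c2c1` gives 4520 nM, and compound 3 `Cc1ncncc1-c1nc2cc(F)c(F)cc2n1C1CC1` gives 4160 nM, the lower of the two numbers, though its gap to compound 2 lies within the scatter. Within the data shown here, the one measured step, an at least 2.2-fold lower number from compound 1 to compound 2 (0.34 log units; beyond the scatter), concerns another part of the structure and does not cover the change now considered. Compound 4 `Fc1cc2nc(-c3cncnc3C(F)F)n(C3CC3)c2cc1F` differs from compound 3 by difluoromethyl in place of methyl on an aromatic carbon. Among the measured compounds shown here, no measured step bears on this exchange, so in this assay a step of no more than modest size, in either direction, is expected. Compound 4 is therefore estimated at about 3500 nM, between 1200 nM and 10000 nM, a step of a 1.2-fold lower number from compound 3 to compound 4 (0.08 log units; within the scatter).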

Compound 4, half-maximal inhibitory concentration: 4330 nM
Beside the measured number, compound 4's estimate is 1.2-fold (0.09 log units) below it, within the range that was stated.
By their numbers in this assay, from the lowest: compounds 3, 4 and 2 (each within the scatter of the next). At a limit, above all of these: compound 1.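

In this assay, difluoromethyl in place of methyl, on an aromatic carbon next to the ring nitrogen and ortho to a large group, gives a 1.0-fold higher number from compound 3 to compound 4 (0.02 log units; within the scatter) and leaves the two compounds indistinguishable. Among these compounds, this is the first reading at this position, and here methyl and difluoromethyl cannot be told apart on this read-out. Nothing in the data on hand bears on why this step is so small. On these data alone, whether an amine, a carboxylic acid or a longer chain at this position would give a step beyond the scatter remains open, as does whether the same exchange behaves alike elsewhere on the shared core.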